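A Longer Tether to the Nitroimidazole Group

A few compounds are considered here, and "the series" means these few. Any claim that something is new, unique, unknown or untested is made for them only; others in the source may bear on it.

Within the data shown here, compound 2 `COc1cc2ncnc(Nc3ccc(F)c(Cl)c3)c2cc1OCCCn1c([N+](=O)[O-])cnc1C` gives 23200 nM in a functional assay on HT-29 cells (Homo sapiens) for cytotoxicity, read by sulforhodamine B assay, with a stated time of 72 h (a lower number here means a stronger inhibitor, a higher number a weaker inhibitor), numerically the top of only two numbers. Compound 1 `COc1cc2ncnc(Nc3ccc(F)c(Cl)c3)c2cc1OCCCCCn1ccnc1[N+](=O)[O-]` gives 17600 nM in this assay, and a 1.3-fold higher number from compound 1 to compound 2 (0.12 log units; within the scatter) does not separate the pair. Compound 3 `COc1cc2ncnc(Nc3ccc(F)c(Cl)c3)c2cc1OCCCCn1c([N+](=O)[O-])cnc1C` differs from compound 2 by (2-methyl-5-nitro-1H-imidazol-1-yl)methyl in place of 2-methyl-5-nitro-1H-imidazol-1-yl on a saturated chain carbon, three bonds along the chain from an oxygen on an aromatic ring; cut one bond further out, the same change reads (2-methyl-5-nitro-1H-imidazol-1-yl)methyl to 2-(2-methyl-5-nitro-1H-imidazol-1-yl)ethyl. Among the measured compounds shown here, the single measured step, a 1.3-fold higher number from compound 1 to compound 2 (0.12 log units; within the scatter), altered tether and nitroimidazole together and stayed within the scatter, so nothing beyond the scatter is expected here. Compound 3 is therefore estimated at 20000 nM, between 8000 nM and 50000 nM, an expected step of a 1.2-fold lower number from compound 2 to compound 3 (0.06 log units; within the scatter).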

Compound 3, half-maximal inhibitory concentration: 8210 nM
Estimate against measurement, compound 3: 2.4-fold (0.39 log units) above, and the stated range covers the measured number.
By their numbers in this assay, from the lowest: compound 3; then compounds 1 and 2 (each within the scatter of the next).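

Lengthening the saturated chain that carries the 2-methyl-5-nitro-1H-imidazol-1-yl group gives the first step beyond the scatter in this assay, a 2.8-fold lower number from compound 2 to compound 3 (0.45 log units; beyond the scatter). The change from the 2-nitro-1H-imidazol-1-yl compound is also beyond the scatter, a 2.1-fold lower number from compound 1 to compound 3 (0.33 log units; beyond the scatter), although tether and nitroimidazole differ together there. Nothing available explains either step.

The compounds shown leave open whether a longer chain carrying the same 2-methyl-5-nitro-1H-imidazol-1-yl group would lower the number further. They also leave open whether an amine in place of the nitro group would preserve this step.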